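Pyridin-2-yl for Phenyl on the Ketone of Compound 2

The source may report more compounds than this note shows. Statements on the series, on what has been measured and on what is new or still open speak of the compounds shown alone.

The measured compounds and their values:
compound 1 `CC(=O)CC1CC(=O)N(c2ccccc2)C1=O` — 63900 nM
compound 2 `NS(=O)(=O)c1ccc(N2C(=O)CC(CC(=O)c3ccccc3)C2=O)cc1` — 4230 nM
compound 3 `O=C1CCCCC1C1CC(=O)N(c2ccccc2)C1=O` — 45100 nM

All three were tested in an assay on Sf21 cells for inhibition of cytochrome c oxidase subunit 2 (Homo sapiens), read by spectrophotometry, with a stated time of 5 min; a lower number here means a stronger inhibitor, a higher number a weaker inhibitor. Compound 2 gives the lowest number of the three, 4230 nM; its gaps to compound 3, which gives 45100 nM, and to compound 1, which gives 63900 nM, both lie beyond the usual scatter, so compound 2 is the strongest inhibitor among those measured.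

Compound 4 `NS(=O)(=O)c1ccc(N2C(=O)CC(CC(=O)c3ccccn3)C2=O)cc1` differs from compound 2 in one place: pyridin-2-yl in place of phenyl on a carbonyl carbon. Cut one bond further out, the change reads benzoyl to (pyridin-2-yl)carbonyl. Among the measured compounds shown here, no pair of measured compounds shows this change, so its effect in this assay is not known from the data at hand. Given how little of the rest of the molecule is touched, the step from compound 2 to compound 4 is expected to be small, in either direction, and likely within the scatter: a 1.2-fold higher number from compound 2 to compound 4 (0.07 log units; within the scatter). Compound 4 is therefore estimated at 5000 nM, with a range from 1500 nM to 16000 nM.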

Compound 4, half-maximal inhibitory concentration: 8940 nM
Beside the measured number, compound 4's estimate is 1.8-fold (0.25 log units) below it, within the range that was stated.
By their numbers in this assay, from the lowest: compound 2; then compound 4; then compounds 3 and 1 (each within the scatter of the next).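

In this assay, pyridin-2-yl in place of phenyl on a carbonyl carbon gives a 2.1-fold higher number from compound 2 to compound 4 (0.32 log units; beyond the scatter), a modest step. Among the compounds shown here, this is the first comparison that isolates a single change at this position, as the earlier compounds offered no pair differing in one place only; it shows that the number responds to the ring on this carbonyl carbon, even though the entering ring keeps the 6 heavy atoms of phenyl and differs by 1 ring nitrogen and 1 hydrogen-bond acceptor. No measurement at hand accounts for the step.

The compounds shown leave open whether pyridin-3-yl or pyridin-4-yl on the same carbonyl carbon would give a number closer to that of compound 2 or of compound 4. They also leave open how a saturated ring such as cyclohexyl would compare there.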